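A few compounds are considered here, and "the series" means these few. Any claim that something is new, unique, unknown or untested is made for them only; others in the source may bear on it.

Measured compounds in a functional assay on MCF7 cells (Homo sapiens) for antiproliferative activity, read by sulforhodamine B assay, with a stated time of 48 h, tested at 50 uM; on this read-out lower numbers stand for less inhibition and higher numbers for more inhibition at the one concentration tested (going by the name of the read-out):
compound 1 `COc1cccc(C(=O)Oc2cc3c(cc2C)[C@@H](C(C)C)CC=C3C)c1` gives 11.9%
compound 2 `CC1=CC[C@H](C(C)C)c2cc(C)c(OC(=O)c3ccc(C)cc3)cc21` gives 65%
compound 3 `CC1=CC[C@H](C(C)C)c2cc(C)c(OC(=O)Nc3ccccc3)cc21` gives 75.1%

Compound 2 stands second highest of the three numbers in this assay: compound 3 sits above it by a number 10.1 percentage points higher from compound 2 to compound 3 (beyond the scatter), and compound 1 sits well below it, as shown by a number 53.1 percentage points higher from compound 1 to compound 2 (beyond the scatter). Compound 4 `CC1=CC[C@H](C(C)C)c2cc(C)c(OC(=O)c3ccc(C(F)(F)F)cc3)cc21` differs from compound 2 by trifluoromethyl in place of methyl on an aromatic carbon. Within the data shown here, no measured step touches this change directly. The steps from compound 1 to compound 2 and from compound 1 to compound 3 swap the whole aryl group, and the step from compound 2 to compound 3 exchanges the aryl for an anilino group. Among the measured compounds shown here, each was large, which shows that this part of the molecule moves the read-out, but no pair of compounds distinguishes one substituent on the phenyl ring from another. The expectation for compound 4 is therefore a step of a number 5 percentage points lower from compound 2 to compound 4 (within the scatter) that may fall within the scatter, with wide uncertainty. Compound 4 is estimated at 60%, in the range 35% to 85%.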

Compound 4, a percentage reported as inhibition, at one concentration (the size of the read-out at that concentration, not a potency): 40.4%
For compound 4 the middle estimate is 19.6 percentage points above the measured one; measured number inside the range.
By their numbers in this assay, from the lowest: compound 1; then compound 4; then compound 2; then compound 3.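

In this assay, trifluoromethyl in place of methyl on the aromatic carbon para to a large group gives a number 24.6 percentage points lower from compound 2 to compound 4 (beyond the scatter) with the rest of the molecule unchanged. A single substituent on this phenyl ring therefore moves the read-out by itself, which the earlier swaps of whole aryl and anilino groups could not show. Nothing available explains the size or direction of this step.

Going by these compounds, whether chlorine, an amine or a carboxylic acid at this place would lie nearer compound 2 or compound 4 remains open. So does whether trifluoromethyl on the phenyl ring of compound 3 would give a similar step.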